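The source may report more compounds than this note shows. Statements on the series, on what has been measured and on what is new or still open speak of the compounds shown alone.

Measured so far:
compound 1, `CCCCCNc1cnc(C(=O)NCc2ccccc2)cn1`: > 100000 nM
compound 2, `CCCCCCCCNc1nccnc1C(=O)NCc1ccccc1`: > 100000 nM

The account follows the step from compound 1 to compound 3. In an ADME assay on HEL cells (Homo sapiens) for cytotoxicity, read by microscopy, with a stated time of 6 days (a higher number here means that more compound is tolerated, a lower number that less compound is tolerated), compound 1 gives > 100000 nM, and this is a limit of the assay rather than a number. Compound 2 likewise stops at a limit, since in this assay compound 2 gives > 100000 nM. Going by the values given here, both values sit at the limit of > 100000 nM in this assay, at which 2 of the 2 values shown sit, so compound 1 stands exactly where the only other measured compound stands, at the edge of what the assay can report, and no ordering between the two can be read from the numbers. Among the compounds with values here, no step between measured compounds can be stated. Neither value is a number.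

Compound 3, `CCCCCCNc1cnc(C(=O)NCc2ccccc2)cn1`, has not yet been measured. It differs from compound 1 by methyl in place of hydrogen on a saturated chain carbon, five bonds along the chain from a nitrogen on an aromatic ring. With both measured values at a limit and a change of this small kind, the step of a number no higher from compound 1 to compound 3 (the limit leaves the size open) is expected to stay within the usual scatter, in no particular direction. Compound 3 is therefore expected to give 100000 nM, with a range from 50000 nM to 200000 nM, and most probably the assay will again report only a limit.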

Compound 3, minimum cytotoxic concentration: > 100000 nM
Compound 3: a limit, no number; the forecaster's own chance of this, stated with the estimate: 85%; the middle value sits exactly at the limit.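

Going by these compounds alone, compound 3, like compound 1, stops at a limit in this assay, so no step between the two can be read: the limit of > 100000 nM in this assay, at which 3 of the 3 values shown sit. The compounds shown leave open what concentration of any of them is actually tolerated in this assay, and so whether methyl in place of hydrogen on the chain changes it at all.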